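Methoxy on the shared core: from compound 1 to compound 4

The compounds below may be only part of what the source reports. "The series", "measured", "known", "first", "only" and "open" are said of these compounds alone.

Measured compounds:
compound 1 `N[C@@H]1CCN(c2cc3c(cc2F)c(=O)c(C(=O)O)cn3Cc2ccc(-c3ccccc3)cc2)C1` — 63600 nM
compound 2 `NC[C@@H]1CCN(c2ccc3c(=O)c(C(=O)O)cn(Cc4ccc(-n5cccn5)cc4)c3c2)C1` — 61000 nM
compound 3 `CNC(=O)c1cn(Cc2ccc(-c3ccccc3)cc2)c2c(OC)c(N3CC[C@@H](CN)C3)c(F)cc2c1=O` — 82100 nM

All three values come from an assay on isolated protein for inhibition of DNA topoisomerase 1 (Homo sapiens), with a stated time of 15 min; on this read-out higher numbers stand for weaker inhibition and lower numbers for stronger inhibition. The three numbers lie within the usual scatter of one another, so no order among them can be read: compound 1 is not separated from compound 2, whose number is the nearest, nor from compound 3, whose number is the furthest of the three, and neither gap exceeds the scatter. Within the data shown here, no step between compounds that differ in a single place has been measured, so there is no directly comparable change to lean on.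

The next compound, compound 4 `COc1c(N2CC[C@@H](N)C2)c(F)cc2c(=O)c(C(=O)O)cn(Cc3ccc(-c4ccccc4)cc3)c12`, is derived from compound 1 by one change: methoxy in place of hydrogen on an aromatic carbon. Compound 3, which also carries a methoxy on its core together with other differences, gives a number close to that of compound 1, which offers no hint that the methoxy alone moves this read-out. The expected step from compound 1 to compound 4 is therefore a 1.1-fold lower number from compound 1 to compound 4 (0.03 log units; within the scatter), that is, no change beyond the scatter in either direction. Compound 4 is expected to give 60000 nM, with a plausible range from 25000 nM to 150000 nM.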

Compound 4, half-maximal inhibitory concentration: 92200 nM
For compound 4 the middle estimate is 1.5-fold (0.19 log units) below the measured one, within the range that was stated.
By their numbers in this assay, from the lowest: compounds 2, 1, 3 and 4 (each within the scatter of the next).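

Among these compounds, the only single-place step in this assay is a 1.4-fold higher number from compound 1 to compound 4 (0.16 log units; within the scatter), so on this read-out methoxy in place of hydrogen on this aromatic carbon, ortho to the 3-aminopyrrolidin-1-yl group and meta to the fluoro group, cannot be told apart from hydrogen. Among the compounds shown here, this is the first direct reading of the position, since the earlier compounds differ from one another in more than one place and none isolates the methoxy as the sole difference. No measurement is available that bears on why the step stays within the scatter.

Still open, from the compounds shown here alone, is whether another group on this same aromatic carbon, such as ethoxy, chloro or dimethylamino, would give a step beyond the scatter, as a single methoxy case says nothing about other groups there. Also open, going by these compounds, is whether methoxy in place of hydrogen reads the same once the carboxylic acid gives way to a primary amide, or once the 3-aminopyrrolidin-1-yl group gives way to a dimethylamino group.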